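The source may report more compounds than this note shows. Statements on the series, on what has been measured and on what is new or still open speak of the compounds shown alone.

In a functional assay on A549 cells (Homo sapiens) for antiproliferative activity, read by MTT assay, with a stated time of 48 h (on this read-out higher numbers stand for weaker inhibition and lower numbers for stronger inhibition), compound 3 (`O=C(/C=C/c1ccccc1)Nc1nnc(-c2ccccc2)s1`) gives 1.75 ug/mL. This lies within the scatter of compound 2 (`Cc1ccc(/C=C/C(=O)Nc2nnc(-c3ccc(C)cc3)s2)cc1`) at 1.08 ug/mL, whereas compound 1 (`COc1ccc(-c2nnc(NC(=O)/C=C/c3ccc(C)cc3)s2)cc1`) at 0.58 ug/mL lies beyond the scatter of compound 3, with the lower number. Compound 4 (`Cc1ccc(/C=C/C(=O)Nc2nnc(-c3ccccc3)s2)cc1`) differs from compound 3 by methyl in place of hydrogen on an aromatic carbon, phenyl to 4-methylphenyl. Among the measured compounds shown here, the only measured step, a 1.9-fold higher number from compound 1 to compound 2 (0.27 log units; within the scatter), is a different change at a different carbon, so it bears only indirectly. Compound 2 carries this methyl and a further one, yet its 1.08 ug/mL stays within the scatter of compound 3. No step beyond the scatter is therefore expected in this assay. The expected step is a 1.3-fold lower number from compound 3 to compound 4 (0.10 log units; within the scatter). Compound 4 is estimated at 1.4 ug/mL, with an expected range of 0.7 ug/mL to 2.6 ug/mL.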

Compound 4, half-maximal inhibitory concentration: 1.58 ug/mL
Beside the measured number, compound 4's estimate is 1.1-fold (0.05 log units) below it; the measured number falls inside the stated range.
By their numbers in this assay, from the lowest: compounds 1, 2, 4 and 3 (each within the scatter of the next, the first and the last beyond it).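

In this assay the added methyl at this aromatic carbon, taken alone, changes little (a 1.1-fold lower number from compound 3 to compound 4 (0.04 log units; within the scatter)). Among the compounds shown here, on the other aromatic ring, the hydrogen of compound 4 in place of methyl also stays within the scatter (a 1.5-fold higher number from compound 2 to compound 4 (0.17 log units; within the scatter)), while hydrogen in place of methoxy is the only one of these steps beyond it, and modestly (a 2.7-fold higher number from compound 1 to compound 4 (0.44 log units; beyond the scatter)). No measured evidence on these compounds bears on these steps. Open, on these data alone, is whether an amine or a carboxylic acid at this aromatic carbon would move the number beyond the scatter. Also open, as far as these compounds go, is whether methoxy on the other ring keeps its step when this methyl is absent.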